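A few compounds are considered here, and "the series" means these few. Any claim that something is new, unique, unknown or untested is made for them only; others in the source may bear on it.

Of the compounds shown here, three sharing one core have been tested in a functional assay on the whole organism (strain Wistar) for inhibition, with Rattus norvegicus as the target, read by paw edema, with a stated time of 4 h, at a dose of 100 mg/kg; a lower number here means less inhibition, a higher number more inhibition at the dose given (going by the name of the read-out). Compound 2 `COc1cc2c(cc1OC)C(CC(=O)Nc1ccccc1C)CC2` gives 25%. Compound 1 `COc1cc2c(cc1OC)C(CC(=O)Nc1cccc(Cl)c1)CC2` gives 25.8%, and compound 3 `COc1cc2c(cc1OC)C(CC(=O)Nc1ccc([N+](=O)[O-])cc1)CC2` gives 37.5%. Compound 2 thus shows the lowest of the three numbers, yet the step of a number 0.8 percentage points lower from compound 1 to compound 2 (within the scatter) lies within the scatter, so compound 2 and compound 1 cannot be told apart; only compound 3 stands clearly higher. Compound 4 `COc1cc2c(cc1OC)C(CC(=O)Nc1cccnc1)CC2` has not been measured. It differs from compound 2 by pyridin-3-yl in place of 2-methylphenyl on an amide-type nitrogen. Going by the values given here, no measured step swaps an all-carbon ring for a nitrogen-containing one, so the only guide is the narrow spread among the three measured compounds. Compound 4 is therefore expected to give 30%, with a range from 15% to 45%. The step of a number 5 percentage points higher from compound 2 to compound 4 (within the scatter) is expected to stay within the scatter.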

Compound 4, a percentage reported as inhibition, in the whole organism at one dose (the size of the read-out at that dose, not a potency): 34.4%
Beside the measured number, compound 4's estimate is 4.4 percentage points below it, and the stated range covers the measured number.
By their numbers in this assay, from the lowest: compounds 2, 1, 4 and 3 (each within the scatter of the next, the first and the last beyond it).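

Neither a number 9.4 percentage points higher from compound 2 to compound 4 (within the scatter) nor a number 8.6 percentage points higher from compound 1 to compound 4 (within the scatter) separates pyridin-3-yl from the two carbon-only rings. On this amide-type nitrogen, then, a ring holding a nitrogen atom gives a number that cannot be told apart from theirs in this assay, and nothing is lost beyond the scatter.

Going by these compounds, whether pyridin-4-yl, or a carboxylic acid on the phenyl ring, would give a different number remains open. Nothing available explains the numbers seen with these rings.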